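From 4-chlorophenyl to 4-hydroxyphenyl

The source may hold more compounds than are shown below. What is called first, only, known or untested is meant among the compounds shown, and "the series" means these compounds.

In a functional assay on A549 cells (Homo sapiens) for inhibition, read by MTT assay, with a stated time of 48 h (a lower number here means a stronger inhibitor, a higher number a weaker inhibitor), compound 1 `COc1cc(-c2nccn3cc(-c4ccc(Cl)cc4)nc23)cc(OC)c1OC` gives 7290 nM, the higher of the two actual numbers in this small set. Compound 2 `COc1cc(-c2nccn3cc(-c4ccc5[nH]ccc5c4)nc23)cc(OC)c1OC` is far lower, at 154 nM. Compound 3 `COc1cc(-c2nccn3cc(-c4ccc(C(F)(F)F)cc4)nc23)cc(OC)c1OC` is reported only as a limit, > 10000 nM.

Compound 4 `COc1cc(-c2nccn3cc(-c4ccc(O)cc4)nc23)cc(OC)c1OC` keeps the core of compound 1 and differs from it in one group: hydroxy in place of chloro on an aromatic carbon, para to a large group (hydroxy in place of chloro on an aromatic carbon).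

For the measured compounds named here, no measured step makes this exact exchange, but three bear on it. Trifluoromethyl in place of chloro gives an at least 1.3-fold higher number from compound 1 to compound 3 (0.13 log units; that floor lies within the scatter), so that single-group exchange shows no clear change. Replacing the whole 4-chlorophenyl with 1H-indol-5-yl gives a 47-fold lower number from compound 1 to compound 2 (1.68 log units; beyond the scatter), a large gain. Going on to 4-(trifluoromethyl)phenyl gives an at least 64-fold higher number from compound 2 to compound 3 (1.81 log units; beyond the scatter), a large loss. Going by the values given here, the number can therefore move strongly with the group at this place, though the one small exchange on record did not clearly move it.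

A moderate shift towards a lower number is expected, well short of the indole step, and the estimated size is a 2.9-fold lower number from compound 1 to compound 4 (0.46 log units; beyond the scatter). For compound 4 the expected value in this assay is 2500 nM, with an estimated range from 400 nM to 10000 nM.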

Compound 4, half-maximal inhibitory concentration: > 10000 nM
Compound 4: only a limit was reported (the forecaster's own chance of this, stated with the estimate: 15%); middle value at least 4.0-fold (0.60 log units) from the limit.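

In this assay, the exchange of chloro for hydroxy brings in a hydrogen-bond donor and acceptor on the same aromatic carbon, yet it gives an at least 1.3-fold higher number from compound 1 to compound 4 (0.13 log units; that floor lies within the scatter), so this exchange shows no gain and its floor does not show a clear loss either. Measured against the indole, 4-hydroxyphenyl gives an at least 64-fold higher number from compound 2 to compound 4 (1.81 log units; beyond the scatter), so among the compounds shown, only the 1H-indol-5-yl of compound 2 gives a low number at this place, and a hydroxy on the six-membered ring does not reproduce it. Compound 3 and compound 4 both stand at a limit rather than a number, so the step between them cannot be read: the limit of > 10000 nM in this assay, at which 2 of the 4 values shown sit.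

On these data alone, it remains open how an amine, a methoxy group or a carboxylic acid in place of chloro would read in this assay, and whether any of them would give a number rather than a limit. Also open, as far as these compounds go, is whether the low number of compound 2 would survive a methyl group on the indole nitrogen, which would show whether the hydrogen there matters.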